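Cyclopentyloxy in Place of Phenyl on Two Cores

This account rests on a few compounds, and the source may have more. Where it says the series, first, only, none or still open, it means among the compounds named here.

Compound 1, `c1ccc(-c2ccc(NC3=NCCO3)cc2)cc1`: 8800 nM
Compound 2, `c1cc(OC2CCCC2)ccc1NC1=NCCO1`: 21100 nM
Compound 3, `O=C(CCl)NC(=O)Nc1ccc(-c2ccccc2)cc1`: 1400 nM

Of the compounds shown here, three have been measured in a functional assay on M21 cells (Homo sapiens) for inhibition, read by sulforhodamine B assay, with a stated time of 48 h; on this read-out higher numbers stand for weaker inhibition of growth and lower numbers for stronger inhibition of growth. Compound 1 gives 8800 nM, compound 2 gives 21100 nM, and compound 3 gives 1400 nM, the lowest of the three numbers. Compound 2 arises from compound 1 by one change: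

cyclopentyloxy in place of phenyl on an aromatic carbon

This change made a 2.4-fold higher number from compound 1 to compound 2 (0.38 log units; beyond the scatter) in this assay.

Compound 4, `O=C(CCl)NC(=O)Nc1ccc(OC2CCCC2)cc1`, has not yet been measured. It arises from compound 3 by the same kind of change:

cyclopentyloxy in place of phenyl on an aromatic carbon

The surroundings are not identical: in compound 1 the group sits para to a group of 6 heavy atoms, while in compound 3 it sits para to a group of 8 heavy atoms. The difference between the core of compound 1 and the core of compound 3 is not broken down here.

For compound 4 in this assay the expectation is a step of a 2.4-fold higher number from compound 3 to compound 4 (0.39 log units; beyond the scatter), because the same change gave a 2.4-fold higher number from compound 1 to compound 2 (0.38 log units; beyond the scatter). The estimate for compound 4 is therefore 3400 nM, expected to lie between 1400 nM and 8500 nM.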

Compound 4, concentration for 50% growth inhibition: 2900 nM
Beside the measured number, compound 4's estimate is 1.2-fold (0.07 log units) above it; the range from low to high includes it.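

In this assay, putting cyclopentyloxy in place of phenyl on an aromatic carbon gave a 2.1-fold higher number from compound 3 to compound 4 (0.32 log units; beyond the scatter). The change therefore carried from one core to the other with its direction kept and no difference in size that can be told apart from the scatter: the same change on two cores in this assay, a 2.4-fold higher number (0.38 log units; beyond the scatter) from compound 1 to compound 2 and a 2.1-fold higher number (0.32 log units; beyond the scatter) from compound 3 to compound 4, 1.2-fold (0.06 log units) apart, within the scatter of two such steps. Among the compounds shown here, this agreement rests on only two pairs in a single assay, so it does not show that the step would hold on other cores, and it does not explain why the swap weakens growth inhibition on either core.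

The compounds shown leave open how other groups would behave at this place on the ring, such as an amine, a carboxylic acid or a longer alkoxy chain, and whether they would track each other across the two cores in the same way. They also leave open which part of the cyclopentyloxy group, its oxygen or its five-membered ring, accounts for the step.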